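An anilino group on a compound at the assay limit

The source may report more compounds than this note shows. Statements on the series, on what has been measured and on what is new or still open speak of the compounds shown alone.

Compound 1 `O=C(CCCCCNC(=O)Cn1cnc2c(Nc3ccccc3)nc(Nc3ccccc3)nc21)NO` gives 9580 nM
Compound 2 `O=C(CCCCCCNC(=O)Cn1cnc2c(Nc3ccccc3)ncnc21)NO` gives > 50000 nM as a limit

In a functional assay on MCF7 cells (Homo sapiens) for inhibition, read by MTT assay, with a stated time of 48 h (a higher number here means a weaker inhibitor, a lower number a stronger inhibitor), compound 2 has no number, only the limit > 50000 nM of the assay. Compound 3 `O=C(CCCCCCNC(=O)Cn1cnc2c(Nc3ccccc3)nc(Nc3ccccc3)nc21)NO` differs from compound 2 by anilino in place of hydrogen on an aromatic carbon in the form of anilino in place of hydrogen on an aromatic carbon, between two ring nitrogen atoms. With compound 1 at 9580 nM as the guide, a change towards stronger inhibition, beyond the scatter, is expected. The expected size is a step of an at least 6.2-fold lower number from compound 2 to compound 3 (0.79 log units; beyond the scatter) in that direction. Compound 3 is estimated at 8000 nM within a range of 3000 nM to 25000 nM in this measurement.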

Compound 3, half-maximal inhibitory concentration: 9040 nM
Beside the measured number, compound 3's estimate is 1.1-fold (0.05 log units) below it, within the range that was stated.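

In this assay, anilino in place of hydrogen on the aromatic carbon between two ring nitrogen atoms gives an at least 5.5-fold lower number from compound 2 to compound 3 (0.74 log units; beyond the scatter), so this position does respond to the change, and the size of the step is only a minimum. Compound 2 carries a limit of the assay and not a number: the limit of > 50000 nM in this assay, at which 1 of the 3 values shown sits. With anilino in place, (hydroxycarbamoyl)methyl in place of hydroxycarbamoyl on the chain gives a 1.1-fold lower number from compound 1 to compound 3 (0.03 log units; within the scatter). Open, on these data alone, is whether a simple amine or a benzylamino group on that carbon would serve as anilino does, and whether a still longer chain would shift the number.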